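Replacing a Piperidine With a Phenol on the Shared Core

The compounds below may be only part of what the source reports. "The series", "measured", "known", "first", "only" and "open" are said of these compounds alone.

Measured so far, in a functional assay on MIA PaCa-2 cells (Homo sapiens) for antiproliferative activity, read by MTT assay, with a stated time of 24 h; on this read-out lower numbers stand for stronger inhibition and higher numbers for weaker inhibition:
Compound 1, `COc1ccc(-c2noc(-c3ccccc3)n2)cc1OC1CCCC1`, gives only a limit, > 1000000 nM.
Compound 2, `COc1ccc(-c2noc(C3CCNCC3)n2)cc1OC1CCCC1`, gives 540 nM.

Among the compounds with values here, compound 2 thus holds the only actual number in this assay; the other value shown is a limit. Within the data shown here, the single measured step, an at least 1800-fold lower number from compound 1 to compound 2 (3.26 log units; beyond the scatter), is large and beyond the scatter, and the limit side of it is described by the limit of > 1000000 nM in this assay, at which 1 of the 2 values shown sits.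

Compound 3, `COc1ccc(-c2noc(-c3ccc(O)cc3)n2)cc1OC1CCCC1`, is not yet measured. It differs from compound 2 as follows: 4-hydroxyphenyl in place of piperidin-4-yl on an aromatic carbon. This is, in part, a return toward compound 1, since an aromatic carbon ring again takes the place that the piperidin-4-yl group held in compound 2, with a 4-hydroxyphenyl instead of a plain phenyl. The step from compound 1 to compound 2 suggests that losing the piperidin-4-yl group costs a great deal of activity, and the step from compound 2 to compound 3 is therefore expected to run in the weaker direction, probably by a large amount, with a real chance that only a limit is reported. The estimate for compound 3 in this assay is 200000 nM, in a range from 15000 nM to 1000000 nM, which means an expected step of a 370-fold higher number from compound 2 to compound 3 (2.57 log units; beyond the scatter).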

Compound 3, half-maximal inhibitory concentration: 480 nM
The estimate for compound 3 lay 420-fold (2.62 log units) above the measured number, and the stated range ends above it.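

The ring at this position need not contain nitrogen: in this assay, swapping the piperidin-4-yl group for 4-hydroxyphenyl gives a 1.1-fold lower number from compound 2 to compound 3 (0.05 log units; within the scatter), so these two quite different rings cannot be told apart on this read-out. The hydroxy group also carries great weight on its own, since this single change to the phenyl ring gives an at least 2000-fold lower number from compound 1 to compound 3 (3.31 log units; beyond the scatter). Compound 1 gives only a limit, so this step has no exact size: the limit of > 1000000 nM in this assay, at which 1 of the 3 values shown sits.

The compounds shown leave open whether the hydroxy group itself is required, or whether another group on that phenyl ring, such as an amine or a carboxylic acid, would serve as well. The piperidin-4-yl and 4-hydroxyphenyl groups each count one hydrogen-bond donor and one hydrogen-bond acceptor, but these compounds cannot show whether that shared count has anything to do with their matching activity.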